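Aryl groups on the ring nitrogen: compound 1 to compound 4

The source may report more compounds than this note shows. Statements on the series, on what has been measured and on what is new or still open speak of the compounds shown alone.

Compound 1 `COc1cccc(-n2cc(CO/N=C3\CC[C@]4(C)[C@@H](CC/C=C(\C)CC/C=C(\C)CCC=C(C)C)[C@](C)(O)CC[C@H]4C3(C)C)nn2)c1` gives 21700 nM in a functional assay on A549 cells (Homo sapiens) for cytotoxicity, read by MTT assay, with a stated time of 48 h; on this read-out higher numbers stand for weaker inhibition and lower numbers for stronger inhibition.
Compound 2 `CC(C)=CCC/C(C)=C/CC/C(C)=C/CC[C@@H]1[C@@]2(C)CC/C(=N\OCc3cn(-c4ccccc4C#N)nn3)C(C)(C)[C@@H]2CC[C@@]1(C)O` gives 20000 nM in this assay.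
Compound 3 `CC(C)=CCC/C(C)=C/CC/C(C)=C/CC[C@@H]1[C@@]2(C)CC/C(=N\OCc3cn(-c4cccc(C(F)(F)F)c4)nn3)C(C)(C)[C@@H]2CC[C@@]1(C)O` gives 12900 nM in this assay.

Of the three numbers, that of compound 1 is the highest, yet the steps of a 1.1-fold lower number from compound 1 to compound 2 (0.04 log units; within the scatter) and a 1.7-fold lower number from compound 1 to compound 3 (0.23 log units; within the scatter) are both within the scatter, as is a 1.6-fold lower number from compound 2 to compound 3 (0.19 log units; within the scatter), so the three compounds cannot be told apart on these measurements.

Compound 4 `COc1cc(OC)c(-n2cc(CO/N=C3\CC[C@]4(C)[C@@H](CC/C=C(\C)CC/C=C(\C)CCC=C(C)C)[C@](C)(O)CC[C@H]4C3(C)C)nn2)c(OC)c1` differs from compound 1 by 2,4,6-trimethoxyphenyl in place of 3-methoxyphenyl on an aromatic nitrogen. Among the compounds with values here, all three measured steps exchange the group on that same aromatic nitrogen, and each remains within the scatter; they are the only steps that bear on this one. On that basis no step beyond the scatter is expected in this assay, in either direction.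

Compound 4 is therefore expected to give 18000 nM, in a range from 8000 nM to 45000 nM. This estimate means a step of a 1.2-fold lower number from compound 1 to compound 4 (0.08 log units; within the scatter), expected to stay within the scatter.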

Compound 4, half-maximal inhibitory concentration: 8120 nM
The estimate for compound 4 lay 2.2-fold (0.35 log units) above the measured number, within the range that was stated.
By their numbers in this assay, from the lowest: compounds 4, 3, 2 and 1 (each within the scatter of the next, the first and the last beyond it).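

In this assay the group on this aromatic nitrogen now shows its first change beyond the scatter, with 2,4,6-trimethoxyphenyl entering: a 2.7-fold lower number from compound 1 to compound 4 (0.43 log units; beyond the scatter) and a 2.5-fold lower number from compound 2 to compound 4 (0.39 log units; beyond the scatter) are both modest. The same group set against the 3-(trifluoromethyl)phenyl group gives a 1.6-fold lower number from compound 3 to compound 4 (0.20 log units; within the scatter) and so does not separate compound 4 from compound 3, which means the four aryl groups do not fall into two clear sets. No measurement at hand offers an explanation for these steps.

As far as these compounds go, whether all of the added methoxy groups are needed for the step, or only some of them, stays open. Also open, from the compounds shown here alone, is how this assay responds when the aryl ring on the nitrogen gives way to a non-aromatic group such as a longer alkyl chain, an amine or a carboxylic acid.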